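Opening notes on a bile acid receptor amide series

The compounds below may be only part of what the source reports. "The series", "measured", "known", "first", "only" and "open" are said of these compounds alone.

Measured so far:
compound 1, `CCOc1cccc(-c2ccc(CN(C(=O)C3CCCCC3)c3cccc(/C=C/C(=O)OC)c3)cc2)c1`, 147 nM
compound 2, `CCOc1cccc(-c2ccc(CN(C(=O)C(C)C)c3cccc(/C=C/C(=O)OC)c3)cc2)c1`, 173 nM
compound 3, `COC/C=C/c1cccc(N(Cc2ccc(/C=C/C(=O)OC(C)(C)C)cc2)C(=O)C2CCCCC2)c1`, 243 nM

In an assay on isolated protein with Bile acid receptor (Homo sapiens) as the target (a higher number here means that more compound is needed for the effect, a lower number that less compound is needed), compound 1 sits at one end of the three numbers, with compound 2 and compound 3 both within the scatter of it. Compound 4, `COC(=O)/C=C/c1cccc(N(Cc2ccc(C(C)(C)C)cc2)C(=O)C2CCCCC2)c1`, has not been measured. Relative to compound 1 the change is tert-butyl in place of 3-ethoxyphenyl on an aromatic carbon. For the measured compounds named here, the only step measured, a 1.2-fold higher number from compound 1 to compound 2 (0.07 log units; within the scatter), alters the carbonyl substituent and not the biaryl position, so it gives no direct guide. With a whole aromatic ring removed, a moderately higher number is expected for compound 4 in this assay, a 2.0-fold higher number from compound 1 to compound 4 (0.31 log units; beyond the scatter). The estimate for compound 4 is 300 nM, range 120 nM to 900 nM.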

Compound 4, half-maximal effective concentration: > 1000 nM
Compound 4: no number, only a limit; the forecaster's own chance of this, stated with the estimate: 5%; middle value at least 3.3-fold (0.52 log units) away from the limit.
By their numbers in this assay, from the lowest: compounds 1, 2 and 3 (each within the scatter of the next). At a limit, above all of these: compound 4.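

For the compounds shown here, the 3-ethoxyphenyl position is the first place where a change gives a step beyond the scatter. In this assay, tert-butyl in place of 3-ethoxyphenyl on this aromatic carbon gives an at least 6.8-fold higher number from compound 1 to compound 4 (0.83 log units; beyond the scatter), while the carbonyl change gives only a 1.2-fold higher number from compound 1 to compound 2 (0.07 log units; within the scatter). Compound 4 has only a limit, > 1000 nM, so only the lower bound of this step can be read: the limit of > 1000 nM in this assay, at which 1 of the 4 values shown sits.

On these data alone, it remains open whether the ring or the ethoxy group matters at this position. An unsubstituted phenyl, or a phenyl carrying a carboxylic acid or an amine, would separate the two.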